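Stretching the ethyl chain to butyl

The source may report more compounds than this note shows. Statements on the series, on what has been measured and on what is new or still open speak of the compounds shown alone.

In a functional assay on HepG2 cells (Homo sapiens) for antiproliferative activity, read by MTT assay, with a stated time of 48 h (a lower number here means a stronger inhibitor of growth, a higher number a weaker inhibitor of growth), compound 2 (`CCN(Cc1ccc(C(=O)NO)cc1)c1ncc(-c2ccc(C)cc2)s1`) gives 1120 nM and holds the lowest number of the three compounds measured. Compound 1 (`CCCCCN(Cc1ccc(C(=O)NO)cc1)c1ncc(-c2ccc(C)cc2)s1`) gives 7020 nM and compound 3 (`Cc1ccc(-c2cnc(N(CCCCOc3ccccc3)Cc3ccc(C(=O)NO)cc3)s2)cc1`) gives 16600 nM on the same scale. Compound 4 (`CCCCN(Cc1ccc(C(=O)NO)cc1)c1ncc(-c2ccc(C)cc2)s1`) has not yet been measured. It departs from compound 2 by one change: ethyl in place of hydrogen on a saturated chain carbon, two bonds along the chain from a nitrogen on an aromatic ring and this turns ethyl into butyl.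

The nearest evidence comes from compound 1, whose chain runs longer than that of compound 4. Its step, a 6.3-fold lower number from compound 1 to compound 2 (0.80 log units; beyond the scatter) with hydrogen in place of propyl, is modest and spans the chain lengths on either side of compound 4. The step of a 15-fold higher number from compound 2 to compound 3 (1.17 log units; beyond the scatter) is large and points the same way, but it brings in 2-phenoxyethyl, which holds a ring, so it bears less directly. With only these compounds to go on, a modest rise is expected, covering much of the gap from compound 2 to compound 1. The expected step is a 3.1-fold higher number from compound 2 to compound 4 (0.49 log units; beyond the scatter) and it carries the uncertainty of a single neighbouring comparison. The expected value in this assay for compound 4 is 3500 nM within an estimated range of 1500 nM to 8000 nM for repeat measurements.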

Compound 4, concentration for 50% growth inhibition: 4300 nM
Beside the measured number, compound 4's estimate is 1.2-fold (0.09 log units) below it; the measured number falls inside the stated range.
By their numbers in this assay, from the lowest: compound 2; then compounds 4 and 1 (each within the scatter of the next); then compound 3.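

In this assay, the step of a 3.8-fold higher number from compound 2 to compound 4 (0.58 log units; beyond the scatter) shows that adding ethyl on the saturated chain carbon, two bonds along the chain from a nitrogen on an aromatic ring, is enough on its own to raise the number beyond the scatter. The step of a 1.6-fold lower number from compound 1 to compound 4 (0.21 log units; within the scatter) stays within the scatter, so the butyl chain of compound 4 and the longer chain of compound 1 cannot be told apart here, and most of the rise seen with compound 1 is already present at butyl. The step of a 3.9-fold lower number from compound 3 to compound 4 (0.59 log units; beyond the scatter) separates the phenoxy group from chain length, since that one group, on a saturated chain carbon four bonds along the chain from a nitrogen on an aromatic ring, accounts for a difference beyond the scatter. Nothing available gives a reason for any of these steps. From the compounds shown here alone, it remains open whether a chain shorter than the ethyl of compound 2, such as methyl, would give a still lower number. Going by these compounds, it is also open whether an amine or a carboxylic acid in the place of phenoxy would raise the number as phenoxy does.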